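This account rests on a few compounds, and the source may have more. Where it says the series, first, only, none or still open, it means among the compounds named here.

Measured compounds:
compound 1, `CN(C)c1ccc(-c2cccc([N+](=O)[O-])c2)cc1` — > 200000 nM, a limit of the assay
compound 2, `COC(=O)Nc1cccc(-c2ccc(N(C)C)cc2)c1` — 5000 nM

In an assay on COS-7 cells for inhibition of patatin-like phospholipase domain-containing protein 2 (Mus musculus) (on this read-out lower numbers stand for stronger inhibition and higher numbers for weaker inhibition), compound 1 gives only a limit of the assay, > 200000 nM. Compound 2, with (methoxycarbonyl)amino in place of nitro on an aromatic carbon, gives 5000 nM in this assay, which is an at least 40-fold lower number from compound 1 to compound 2 (1.60 log units; beyond the scatter). Compound 2 thus holds the only number shown in this assay; the one further value is a limit, (the limit of > 200000 nM in this assay, at which 1 of the 2 values shown sits).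

Compound 3, `CCOC(=O)Nc1cccc(-c2ccc(N(C)C)cc2)c1`, has not yet been measured in this assay. It differs from compound 2 by methyl in place of hydrogen on a saturated chain carbon bound to an oxygen next to a carbonyl group. For the measured compounds named here, no measured step covers this kind of change: the single measured step, from compound 1 to compound 2, concerns a different group on the aromatic ring, and its size cannot be carried over to the small homologation at the carbamate. Going by the values given here, with no step bearing on it, no change beyond the scatter is expected, and the number for compound 3 is estimated to lie close to that of compound 2, as a step of no change at the digits printed from compound 2 to compound 3 (within the scatter). Compound 3 is therefore expected at 5000 nM, within a range from 2000 nM to 12000 nM.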

Compound 3, half-maximal inhibitory concentration: 3000 nM
The estimate for compound 3 lay 1.7-fold (0.22 log units) above the measured number; measured number inside the range.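

In this assay, for the compounds shown here, methyl in place of hydrogen on a saturated chain carbon bound to an oxygen next to a carbonyl group gives a 1.7-fold lower number from compound 2 to compound 3 (0.22 log units; within the scatter), the first measured change at the carbamate itself, and it stays within the scatter, so methoxycarbonyl and ethoxycarbonyl cannot be told apart here. The large step away from nitro also holds with the ethoxycarbonyl group in place, as an at least 66-fold lower number from compound 1 to compound 3 (1.82 log units; beyond the scatter), so it is not confined to the methoxycarbonyl group of compound 2. Compound 1 gives only a limit of the assay, which makes this step a bound and not a full size: the limit of > 200000 nM in this assay, at which 1 of the 3 values shown sits.

The compounds shown leave open how far the chain on the oxygen can grow, for instance to a propyl, a longer chain or a benzyl group, and whether an amide or a urea could stand in place of the carbamate without moving the number beyond the scatter. They also leave open whether the dimethylamino group carried by all three compounds could give way to a pyrrolidine or a methoxy group.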